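The source may hold more compounds than are shown below. What is called first, only, known or untested is meant among the compounds shown, and "the series" means these compounds.

Measured compounds in a functional assay on CCRF-CEM cells for antagonist activity at C-X-C chemokine receptor type 4 (Homo sapiens), read by calcium flux, with stated times of 25 min and 90 s; a higher number here means a weaker inhibitor, a lower number a stronger inhibitor: compound 1, `CN(C[C@H]1Cc2c(cccc2N2CCNC(C)(C)C2)CN1)[C@H]1CCCc2cccnc21`, gives 33.9 nM; compound 2, `CN(C[C@H]1Cc2c(cccc2N2C[C@@H]3C[C@H]2CN3)CN1)[C@H]1CCCc2cccnc21`, gives 146 nM.

Compound 2 stands with the highest of the two numbers, and its nearest neighbour is compound 1, reached through a 4.3-fold higher number from compound 1 to compound 2 (0.63 log units; beyond the scatter). Compound 3, `CN(C[C@H]1Cc2c(cccc2N2C[C@H]3C[C@@H]2CN3)CN1)[C@H]1CCCc2cccnc21`, has not yet been measured. Its relation to compound 2 is this: the two compounds have the same atoms and bonds and differ only in configuration as drawn: 2 of 4 stereo elements differ; a stereocentre at a saturated ring carbon is drawn S in compound 2 and R in compound 3; a stereocentre at a saturated ring carbon is drawn S in compound 2 and R in compound 3. In other words, the bicyclic amine on the shared core is kept, but its handedness is reversed. Among the measured compounds shown here, no measured pair shows what such a reversal of configuration does here; the only measured step, from compound 1 to compound 2, swaps one ring system for another rather than flipping stereocentres, so it does not bear on this change. With nothing to point in either direction, no step beyond the scatter is assumed, though a mirror-image amine could move the number either way. Compound 3 is therefore expected to give roughly 150 nM in this assay, within a range of 40 nM to 600 nM, which amounts to an expected step of a 1.0-fold higher number from compound 2 to compound 3 (0.01 log units; within the scatter).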

Compound 3, half-maximal inhibitory concentration: 20.7 nM
Estimate against measurement, compound 3: 7.2-fold (0.86 log units) above; measured number outside the range, below it.
By their numbers in this assay, from the lowest: compounds 3 and 1 (each within the scatter of the next); then compound 2.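

In this assay, the handedness of the bicyclic amine on the shared core matters in its own right: reversing it gives a 7.1-fold lower number from compound 2 to compound 3 (0.85 log units; beyond the scatter). This step can be traced to configuration alone, something the earlier swap of one ring system for another could not show, because no atom or bond changes: the fact that compounds 2 and 3 differ only in the configuration as drawn

With this handedness, the bicyclic group in place of the six-membered ring on the aromatic carbon gives a 1.6-fold lower number from compound 1 to compound 3 (0.21 log units; within the scatter), so the weaker number of compound 2 is not a general cost of the ring swap.

The compounds shown leave open whether the preference for one hand would carry over to a bicyclic amine with a longer bridge. They also leave open how a morpholine on the same aromatic carbon would compare.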